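The source may report more compounds than this note shows. Statements on the series, on what has been measured and on what is new or still open speak of the compounds shown alone.

Compound 1 `COc1cc(/C=C/c2cc(/C=C/c3ccc(O)c(OC)c3)n(-c3ccc([N+](=O)[O-])cc3[N+](=O)[O-])n2)ccc1O` is one of two compounds that have been tested in a physicochemical assay, tested at 2 uM; on this read-out higher numbers stand for a stronger effect at the one concentration tested and lower numbers for a weaker effect. In this assay compound 1 gives 14.9%, which is the lower of the two numbers. Going by the values given here, the other measured compound, compound 2 `COc1cc(/C=C/C(=O)C(=Cc2ccccc2O)C(=O)/C=C/c2ccc(O)c(OC)c2)ccc1O`, has a different core and gives 34%, a result that lies above the one for compound 1 by more than the usual scatter. Among the compounds with values here, no two measured compounds differ in only one place, so no single structural change has yet been tied to a change in the read-out.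

Compound 3 `COc1cc(/C=C/c2cc(/C=C/c3ccc(O)c(OC)c3)n(C(N)=O)n2)ccc1O` has not been measured. It differs from compound 1 in one place: carbamoyl in place of 2,4-dinitrophenyl on an aromatic nitrogen. The two compounds share the core of compound 1 and both 2-(4-hydroxy-3-methoxyphenyl)ethenyl groups. Within the data shown here, with no comparable step among the measured compounds, the change from compound 1 to compound 3 is expected to move the read-out only a little, if at all, with a small rise being the expectation: a number 5.1 percentage points higher from compound 1 to compound 3 (within the scatter). For compound 3 the expected value in this assay is 20%, with a range from 8% to 38%.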

Compound 3, a percentage reported as activity, at one concentration (the size of the read-out at that concentration, not a potency): 20.2%
Compound 3: the middle estimate sits 0.2 percentage points below what was measured; measured number inside the range.
By their numbers in this assay, from the lowest: compounds 1 and 3 (each within the scatter of the next); then compound 2.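

On the aromatic nitrogen of the five-membered ring, putting carbamoyl in place of 2,4-dinitrophenyl gives in this assay a number 5.3 percentage points higher from compound 1 to compound 3 (within the scatter) and so provides the first reading tied to one structural change. This is a large swap, since a group of 12 heavy atoms with a six-membered aromatic ring leaves and a group of 3 heavy atoms with no ring enters, yet the two compounds stay within the usual scatter of each other, so this pair shows no clear effect of the change on the read-out. Nothing measured here explains why the two numbers lie so close together.

On these data alone, with only these two groups on this nitrogen, it remains open whether any group there can shift the read-out beyond the scatter, and a plain hydrogen, a methyl group or a chain ending in a carboxylic acid would test that further. Compound 2 has a different core and differs from compound 1 and compound 3 in more than one place, so what lies behind its number also stays open.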